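Pyridine-series notes: ring swap on the anilinic nitrogen

The source may report more compounds than this note shows. Statements on the series, on what has been measured and on what is new or still open speak of the compounds shown alone.

Among the compounds with values here, compound 3 `N#Cc1cnc(NCc2cnccc2C(F)(F)F)cc1NCC1CCOCC1` is the one member of this small set with a numeric read-out: in an assay on isolated protein for inhibition of protein kinase C delta type (Homo sapiens), read by TR-FRET, with a stated time of 2 h (on this read-out lower numbers stand for stronger inhibition and higher numbers for weaker inhibition), compound 3 gives 5000 nM. Compound 1 `CO[C@H]1CC[C@H](Nc2cc(NCc3cnccc3C(F)(F)F)ncc2C#N)CC1` is measured only as a limit of this assay, > 10000 nM. Compound 2 `CO[C@H]1CC[C@H](CNc2cc(NCc3cnccc3C(F)(F)F)ncc2C#N)CC1` likewise is reported only as a limit, > 10000 nM. The step from compound 1 to compound 3 is an at least 2.0-fold lower number from compound 1 to compound 3 (0.30 log units; that floor lies within the scatter), and that from compound 2 to compound 3 is an at least 2.0-fold lower number from compound 2 to compound 3 (0.30 log units; that floor lies within the scatter); the pair of compound 1 and compound 2 is left unreadable, a step that the two limits leave unreadable from compound 1 to compound 2, both sitting at the limit of > 10000 nM in this assay, at which 2 of the 3 values shown sit.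

Compound 4 `CC1(C)C[C@H](Nc2cc(NCc3cnccc3C(F)(F)F)ncc2C#N)CC[C@@H]1O` has not yet been measured. It differs from compound 3 by 4-hydroxy-3,3-dimethylcyclohexyl in place of (oxan-4-yl)methyl on a nitrogen on an aromatic ring. Within the data shown here, the change that bears on it most directly is the one from compound 1 to compound 3, where a six-membered carbon ring with an oxygen substituent attached directly to the nitrogen on the aromatic ring gave the limit, and the (oxan-4-yl)methyl group gave the only readable number. Compound 4 returns to a directly attached, oxygen-bearing carbocycle, so a move back toward the limit, a higher number in this assay, is expected; the step from compound 3 to compound 4 is estimated at a 2.0-fold higher number from compound 3 to compound 4 (0.30 log units; within the scatter). Compound 4 is therefore expected to give about 10000 nM, within roughly 3000 nM to 30000 nM, with a real chance that only a limit is returned.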

Compound 4, half-maximal inhibitory concentration: 500 nM
For compound 4 the middle estimate is 20-fold (1.30 log units) above the measured one; measured number outside the range, below it.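

Placing 4-hydroxy-3,3-dimethylcyclohexyl on the nitrogen on an aromatic ring in place of (oxan-4-yl)methyl gives a 10-fold lower number from compound 3 to compound 4 (1.00 log units; beyond the scatter), the first step in this set that reads beyond the scatter. A carbon-only ring attached directly to that nitrogen is thus not tied to the limit: replacing 4-methoxycyclohexyl with this group gives an at least 20-fold lower number from compound 1 to compound 4 (1.30 log units; beyond the scatter), and replacing (4-methoxycyclohexyl)methyl with it gives an at least 20-fold lower number from compound 2 to compound 4 (1.30 log units; beyond the scatter). These last two sizes are floors rather than measured gaps, since each starts from a compound reported only as a limit: the limit of > 10000 nM in this assay, at which 2 of the 4 values shown sit.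

The step from 4-methoxycyclohexyl to 4-hydroxy-3,3-dimethylcyclohexyl alters the 4-substituent and adds the 3,3-dimethyl substitution in a single move, so the compounds shown do not separate the contribution of either change, nor that of the two defined stereocentres. From the compounds shown here alone, how an amine at the 4-position of the same ring, in place of the hydroxy group, would read in this assay also remains open.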